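The source may report more compounds than this note shows. Statements on the series, on what has been measured and on what is new or still open speak of the compounds shown alone.

Measured so far:
Compound 1 `Cc1c(C2CC2)nc2ccc(-n3ccc(OCc4ccc(C(C)C)cc4)cc3=O)cn12` gives 240 nM in an assay on CHO cells for displacement of a labelled ligand from melanin-concentrating hormone receptor 1 (Rattus norvegicus), read by scintillation counting, with a stated time of 1 h; a lower number here means a stronger inhibitor, a higher number a weaker inhibitor.
Compound 2 `Cc1c(C2CC2)nc2ccc(-n3ccc(OCc4cccnc4)cc3=O)cn12` gives > 1000 nM in this assay, which is a limit of the assay and not a number.

Compound 2 thus stands at the weak end of what has been measured: its potency is known only as a limit (the limit of > 1000 nM in this assay, at which 1 of the 2 values shown sits). Among the compounds with values here, the one measured step shows an at least 4.1-fold higher number from compound 1 to compound 2 (0.61 log units; beyond the scatter), so swapping the isopropylphenyl group for a pyridinyl group on the saturated chain carbon bound to the oxygen clearly cost activity.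

Compound 3 `Cc1c(C2CC2)nc2ccc(-n3ccc(OCc4cncnc4)cc3=O)cn12` is not yet measured. It differs from compound 2 in one place: pyrimidin-5-yl in place of pyridin-3-yl on a saturated chain carbon bound to an oxygen on an aromatic ring. Within the data shown here, no measured compound carries a pyrimidinyl group, so no step among the measured ones tests this exact change directly; the only step that bears on it is the one from compound 1 to compound 2, which points toward weak binding for ring replacements of this kind. Because compound 2 already sits at the limit (the limit of > 1000 nM in this assay, at which 1 of the 2 values shown sits), compound 3 is expected to remain weak. The step that the limit leaves unreadable from compound 2 to compound 3 is expected to stay within the scatter. Compound 3 is estimated at 3000 nM, with a range from 800 nM to 15000 nM.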

Compound 3, half-maximal inhibitory concentration: > 1000 nM
Compound 3 ended at the assay's limit; the forecaster's own chance of this, stated with the estimate: 85%; the middle value is on the limit's open side.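

Placing pyrimidin-5-yl where compound 1 carries 4-isopropylphenyl, on the saturated chain carbon bound to the oxygen, gives an at least 4.1-fold higher number from compound 1 to compound 3 (0.61 log units; beyond the scatter) in this assay. The loss seen with pyridin-3-yl is therefore not confined to that one ring: two different nitrogen-containing rings at this place both bind more weakly than the 4-isopropylphenyl group of compound 1. Compound 2 and compound 3 both rest on a limit of the assay and not on a number, so the change from pyridin-3-yl to pyrimidin-5-yl cannot be read: the limit of > 1000 nM in this assay, at which 2 of the 3 values shown sit.

The compounds shown leave open whether the loss goes with removing the isopropyl group or with having nitrogen in the ring, and a plain phenyl group at this place would help to separate the two. They also leave open how weak compound 2 and compound 3 really are, and whether the extra ring nitrogen of pyrimidin-5-yl changes binding at all.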